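This account rests on a few compounds, and the source may have more. Where it says the series, first, only, none or still open, it means among the compounds named here.

Measured so far in an assay on isolated protein for displacement of a labelled ligand from metabotropic glutamate receptor 5 (Homo sapiens), with a stated time of 60 min, tested at 1 uM; a higher number here means more inhibition at the concentration tested (going by the name of the read-out), a lower number less inhibition:
compound 1 `CC1CCN(c2c(S(=O)(=O)c3ccc(F)c(Cl)c3)cnc3cc(Cl)ccc23)CC1` gives 94%
compound 2 `CC1CCN(c2c(S(=O)(=O)c3ccc(C#N)cc3)cnc3cc(Cl)ccc23)CC1` gives 70%

Among the measured compounds shown here, compound 2 stands lowest of the two numbers; the only measured step, a number 24 percentage points lower from compound 1 to compound 2 (beyond the scatter), separates it from compound 1, which is the only comparison available. Compound 3 `CC1CCN(c2c(S(=O)(=O)c3ccc(F)c(F)c3)cnc3cc(Cl)ccc23)CC1` differs from compound 2 by 3,4-difluorophenyl in place of 4-cyanophenyl on a sulfonyl sulfur. This change returns the sulfonyl-bound ring to a dihalogenated phenyl resembling that of compound 1, so the step is expected to run back upward, estimated at a number 18 percentage points higher from compound 2 to compound 3 (beyond the scatter) in this assay. Compound 3 is therefore expected at about 88%, with a range of 74% to 97%.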

Compound 3, a percentage reported as inhibition, at one concentration (the size of the read-out at that concentration, not a potency): 90%
For compound 3 the middle estimate is 2 percentage points below the measured one; the range from low to high includes it.
By their numbers in this assay, from the lowest: compound 2; then compounds 3 and 1 (each within the scatter of the next).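

In this assay, 3,4-difluorophenyl in place of 4-cyanophenyl on the sulfonyl sulfur gives a number 20 percentage points higher from compound 2 to compound 3 (beyond the scatter), so the change seen with the nitrile-bearing ring runs in reverse when a dihalogenated ring returns. Fluoro in place of chloro on an aromatic carbon gives a number 4 percentage points lower from compound 1 to compound 3 (within the scatter), so the two dihalogenated rings are not separated in this assay. Nothing available bears on the reason for either step. Open, going by these compounds, is whether a phenyl carrying a single fluoro, or a methoxy in place of the nitrile, would stand with compound 3 or with compound 2.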